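Swapping the benzyl substituent on a xanthine adenosine A2b ligand

This account rests on a few compounds, and the source may have more. Where it says the series, first, only, none or still open, it means among the compounds named here.

Compound 1 `CCCn1c(=O)c2nc(-c3cnn(Cc4c(F)cccc4F)c3)[nH]c2n(CCC)c1=O` has been measured in an in vitro assay on HEK293 cells for displacement of a labelled ligand from adenosine receptor A2b (Homo sapiens) (on this read-out higher numbers stand for weaker inhibition and lower numbers for stronger inhibition), and gives 390 nM. Compound 2 `CCCCn1c(=O)c2nc(-c3cnn(Cc4ccccc4)c3)[nH]c2n(CCCC)c1=O` differs from it in more than one place, and in this assay compound 2 gives 980 nM. On the two numbers available, compound 1 stands lowest, with compound 2 the nearest at a higher value that lies beyond the usual scatter.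

Compound 3 `CCCn1c(=O)c2nc(-c3cnn(Cc4ccccc4OC)c3)[nH]c2n(CCC)c1=O` is the untested member of the set. Its structure differs from compound 1 in one group: 2-methoxyphenyl in place of 2,6-difluorophenyl on a saturated chain carbon bound to an aromatic nitrogen. Within the data shown here, no single-point step between measured compounds is available to anchor this change, so the expectation rests on compound 1 alone. A small move toward a higher number, not clearly beyond the scatter, is expected, with the step from compound 1 to compound 3 estimated at a 1.4-fold higher number from compound 1 to compound 3 (0.15 log units; within the scatter). Compound 3 is therefore expected to give about 550 nM in this assay, within a range from 150 nM to 2000 nM.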

Compound 3, inhibition constant: 37 nM
For compound 3 the middle estimate is 15-fold (1.17 log units) above the measured one; measured number outside the range, below it.
By their numbers in this assay, from the lowest: compound 3; then compound 1; then compound 2.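

Swapping the benzyl substituent proves far from neutral at this position on a saturated chain carbon bound to an aromatic nitrogen: in this assay, 2-methoxybenzyl in place of 2,6-difluorobenzyl gives an 11-fold lower number from compound 1 to compound 3 (1.02 log units; beyond the scatter), a step well beyond the usual scatter. The two groups have the same heavy-atom count, so a large change in this read-out occurs with no change in that count, while the entering group carries a hydrogen-bond acceptor and the leaving group carries none. Nothing available bears on why this swap has so large an effect.

As far as these compounds go, it remains open whether the gain comes from adding the methoxy group or from removing the two fluorines; compound 2, with its plain benzyl, differs from compound 1 in more than one place. From the compounds shown here alone, how a hydroxy, ethoxy or dimethylamino group would read at this place also remains open.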